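Iodine for bromine on the benzyl ring of a thiourea

A few compounds are considered here, and "the series" means these few. Any claim that something is new, unique, unknown or untested is made for them only; others in the source may bear on it.

Compound 1 `COc1cc(CNC(=S)NC(CCc2ccc(C)c(C)c2)COC(=O)C(C)(C)C)cc(Br)c1O`: in an assay on CHO cells for displacement of a labelled ligand from transient receptor potential cation channel subfamily V member 1 (Rattus norvegicus) (on this read-out higher numbers stand for weaker inhibition and lower numbers for stronger inhibition), compound 1 gives 102 nM.
Compound 2 `COc1cc(CNC(=S)NC(CCc2ccc(C)c(C)c2)COC(=O)C(C)(C)C)c(Br)cc1O`: in this assay compound 2 gives 109 nM.

These two compounds share the same core and differ only in where the bromine sits on the benzyl ring. Compound 2 shows the higher of the two numbers, but the step of a 1.1-fold higher number from compound 1 to compound 2 (0.03 log units; within the scatter) lies within the scatter, so compound 2 and compound 1 are indistinguishable on this read-out.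

Compound 3 `COc1cc(CNC(=S)NC(CCc2ccc(C)c(C)c2)COC(=O)C(C)(C)C)c(I)cc1O` keeps the substitution pattern of compound 2 and carries the change (iodo in place of bromo on an aromatic carbon). For the measured compounds named here, no measured step in this set exchanges one halogen for another; the only step available, from compound 1 to compound 2, moves the bromine around the ring and stays within the scatter. There is therefore nothing here that points to a large effect in this assay, and the swap of one halogen atom for a slightly larger one is expected to leave the number close to that of compound 2, a step of a 1.1-fold lower number from compound 2 to compound 3 (0.04 log units; within the scatter). Compound 3 is accordingly estimated at 100 nM, with a range from 40 nM to 250 nM.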

Compound 3, inhibition constant: 140 nM
For compound 3 the middle estimate is 1.4-fold (0.15 log units) below the measured one; measured number inside the range.
By their numbers in this assay, from the lowest: compounds 1, 2 and 3 (each within the scatter of the next).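

In this assay, for the compounds shown here, the exchange of bromo for iodo, on the aromatic carbon meta to a hydroxy group and para to a methoxy group, gives a 1.3-fold higher number from compound 2 to compound 3 (0.11 log units; within the scatter) and is the first halogen-for-halogen step in this set, showing that this position accepts either halogen without a change that can be read on this measure. The comparison of 4-hydroxy-2-iodo-5-methoxyphenyl with the 3-bromo-4-hydroxy-5-methoxyphenyl group of compound 1, which differs in both the halogen and its place on the ring, gives a 1.4-fold higher number from compound 1 to compound 3 (0.14 log units; within the scatter) and also stays within the scatter, so compounds 1, 2 and 3 cannot be separated in this assay. Nothing available here offers an explanation for this result.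

The compounds shown leave open whether a chloro, a fluoro, a methyl or an amine at this same aromatic carbon would also keep the number within the scatter of compound 2. They also leave open whether iodo would behave as bromo does at the place that bromo holds in compound 1.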